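A few compounds are considered here, and "the series" means these few. Any claim that something is new, unique, unknown or untested is made for them only; others in the source may bear on it.

Measured compounds
Compound 1 `Cc1ncn2c(O)nncc12` — > 48000 nM
Compound 2 `Cc1ncn2c(S)nncc12` — > 48000 nM
Compound 3 `Cc1ncn2c(Nc3cccs3)nncc12` — > 48000 nM

In a functional assay for inhibition, with Homo sapiens as the target (on this read-out higher numbers stand for weaker inhibition and lower numbers for stronger inhibition), compound 1 gives > 48000 nM, which is a limit of the assay and not a number. Compound 2 gives > 48000 nM, likewise a limit. Compound 3 gives > 48000 nM, again a limit. Compound 3 therefore stands at the same limit as the other two values: the limit of > 48000 nM in this assay, at which 3 of the 3 values shown sit. For the measured compounds named here, the only step between compounds that differ in one place, a step that the two limits leave unreadable from compound 1 to compound 2, cannot be read, since both of its ends are limits. Compound 4 `Cc1ncn2c(NN)nncc12` differs from compound 3 by amino in place of thiophen-2-yl on a nitrogen on an aromatic ring. Going by the values given here, no measured step bears on this change, and the one step available is unreadable, so no size or direction can be drawn from the data. The expectation for compound 4 rests only on compound 3 sitting at > 48000 nM. Compound 4 is expected to give 60000 nM, with a range from 20000 nM to 200000 nM, most likely reported as a limit again. The expected step is a step that the limit leaves unreadable from compound 3 to compound 4, not beyond the scatter.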

Compound 4, half-maximal inhibitory concentration: > 48000 nM
Compound 4: a limit, no number; the forecaster's own chance of this, stated with the estimate: 80%; the middle value is on the limit's open side.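

In this assay compound 4 gives > 48000 nM, a limit and not a number. No new step can be read from compound 1, compound 2 or compound 3 to compound 4, all four sitting at one limit: the limit of > 48000 nM in this assay, at which 4 of the 4 values shown sit.

The compounds shown leave open which change on the shared core, if any, would give a measurable value in this assay.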